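The source may hold more compounds than are shown below. What is called first, only, known or untested is meant among the compounds shown, and "the series" means these compounds.

Measured so far in an ADME assay on NIH3T3 cells (Mus musculus) for cytotoxicity; a higher number here means that more compound is tolerated, a lower number that less compound is tolerated:
Compound 1 `CCOC(=O)CN(C)CC#Cc1cc2ncnc(Nc3ccc(OCc4cccc(F)c4)c(Cl)c3)c2s1`: 52 uM
Compound 2 `CCCN(CC#Cc1cc2ncnc(Nc3ccc(OCc4cccc(F)c4)c(Cl)c3)c2s1)CCC`: > 50 uM (a limit)
Compound 3 `COCC#Cc1cc2ncnc(Nc3ccc(OCc4cccc(F)c4)c(Cl)c3)c2s1`: > 50 uM (a limit)

Compound 3 has no exact number in this assay and stands at the limit of > 50 uM in this assay, at which 2 of the 3 values shown sit. The step to compound 4 `Fc1cccc(COc2ccc(Nc3ncnc4cc(C#CCN5CCCC5)sc34)cc2Cl)c1` is a change at the end of the chain: pyrrolidin-1-yl in place of methoxy on a saturated chain carbon bound to a triple-bonded carbon. Among the measured compounds shown here, two measured steps touch the same place, and neither has a readable size: a step that the two limits leave unreadable from compound 2 to compound 3, and a step that the limit leaves unreadable from compound 1 to compound 3. The nearest guide is therefore the amino-bearing compounds. Compound 2, with dipropylamino at this place, gives > 50 uM, which is a limit. Compound 1, with ((ethoxycarbonyl)methyl)(methyl)amino there, gives 52 uM. On these values, no step beyond the scatter is expected in this assay, and no direction can be supported. The expected change is a number no higher from compound 3 to compound 4 (the limit leaves the size open). Compound 4 is estimated at 50 uM, with an expected range from 20 uM to 100 uM.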

Compound 4, half-maximal toxic concentration: 6.4 uM
Beside the measured number, compound 4's estimate is 7.8-fold (0.89 log units) above it; the measured number lies below the stated range.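

In this assay the steps among compound 1, compound 2 and compound 3 cannot be read, and pyrrolidin-1-yl gives this place its only readable ones: an at least 7.8-fold lower number from compound 3 to compound 4 (0.89 log units; beyond the scatter) and an at least 7.8-fold lower number from compound 2 to compound 4 (0.89 log units; beyond the scatter) both start from a limit, while an 8.1-fold lower number from compound 1 to compound 4 (0.91 log units; beyond the scatter) has exact numbers on both sides. The group on the saturated chain carbon bound to a triple-bonded carbon can therefore move the number beyond the scatter while the rest of the molecule stays the same. Compound 1 and compound 2 also carry a nitrogen at this place, so a nitrogen there does not bring the lower number on its own.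

Compound 4 is the only one shown with a ring at this place. From the compounds shown here alone, whether a piperidine, a morpholine or an open dimethylamino group there would follow compound 4 or compound 2 stays open.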